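Thiophene for Phenyl on a Nucleoside Core

The source may report more compounds than this note shows. Statements on the series, on what has been measured and on what is new or still open speak of the compounds shown alone.

Compound 2 `Nc1nc(N)c2c(-c3ccccc3)cn([C@@H]3O[C@H](CO)[C@@H](O)[C@H]3O)c2n1` carries a phenyl group on its core. In a functional assay on CEM-DNR-bulk cells (Homo sapiens), read by MTT assay, with a stated time of 72 h (a higher number here means a weaker inhibitor, a lower number a stronger inhibitor), compound 2 gives > 20000 nM, which is a limit of the assay rather than a number. Compound 1 `Nc1nc(N)c2c(-c3ccsc3)cn([C@@H]3O[C@H](CO)[C@@H](O)[C@H]3O)c2n1` arises from compound 2 by thiophen-3-yl in place of phenyl on an aromatic carbon. In this assay compound 1 gives > 20000 nM, again only a limit. The step that the two limits leave unreadable from compound 2 to compound 1 therefore cannot be read, since the limit of > 20000 nM in this assay, at which 3 of the 3 values shown sit, holds both values. Compound 3 `Nc1nc2c(c(-c3ccccc3)cn2[C@@H]2O[C@H](CO)[C@@H](O)[C@H]2O)c(=O)[nH]1` has a core that differs from that of compound 2; how the two cores differ is not broken down here. In this assay compound 3 gives > 20000 nM, once more a limit. Compound 4 `Nc1nc2c(c(-c3ccsc3)cn2[C@@H]2O[C@H](CO)[C@@H](O)[C@H]2O)c(=O)[nH]1`, not yet measured, is compound 3 altered by thiophen-3-yl in place of phenyl on an aromatic carbon, the same change that turns compound 2 into compound 1. Because the limit of > 20000 nM in this assay, at which 3 of the 3 values shown sit, gathers all three known values, the earlier step gives no size to lean on. Compound 4 is expected to give 30000 nM in this assay, with an expected step that the limit leaves unreadable from compound 3 to compound 4 that is judged small. This expectation rests on compound 3 giving > 20000 nM, a limit.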

Compound 4, half-maximal inhibitory concentration: > 20000 nM
Compound 4 was reported as a limit (the forecaster's own chance of this, stated with the estimate: 85%); the middle value lies beyond the limit too.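

In this assay compound 4 gives > 20000 nM, which is a limit of the assay and not a number. Among the compounds shown here, no step from compound 3 to compound 4 can be read, because both compounds sit at the same limit: the limit of > 20000 nM in this assay, at which 4 of the 4 values shown sit. The compounds shown leave open how strongly any of the four inhibits, and whether thiophen-3-yl in place of phenyl makes any difference on either core.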